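The compounds below may be only part of what the source reports. "The series", "measured", "known", "first", "only" and "open" are said of these compounds alone.

Compound 2 `NC(=O)c1ccc2c(ccn2-c2ccc(NC(=O)c3cccc(C(F)(F)F)c3)cc2)n1` is the starting point. In a functional assay on A375P cells (Homo sapiens) for cytotoxicity, read by MTT assay (a lower number here means a stronger inhibitor, a higher number a weaker inhibitor), compound 2 gives only a limit, > 10000 nM, and not a number. Compound 3 `COC(=O)c1ccc2c(ccn2-c2cccc(NC(=O)Nc3cccc(C(F)(F)F)c3)c2)n1` likewise gives only a limit, > 10000 nM. Compound 1 `COC(=O)c1ccc2c(ccn2-c2ccc(NC(=O)c3ccc(Cl)c(C(F)(F)F)c3)cc2)n1` differs from compound 2 in two places; in this assay compound 1 gives 3000 nM. Compound 2 thus stands at the limit of > 10000 nM in this assay, at which 2 of the 3 values shown sit. Compound 4 `NC(=O)c1ccc2c(ccn2-c2ccc(NC(=O)c3ccc(Cl)c(C(F)(F)F)c3)cc2)n1` is the compound still to be measured; the change is chloro in place of hydrogen on an aromatic carbon. No step of exactly this kind has been measured among these compounds, so the expectation rests on the change alone: a modest gain is expected, an at least 1.2-fold lower number from compound 2 to compound 4 (0.09 log units; that floor lies within the scatter), though this assay may again report only a limit. Compound 4 is accordingly estimated at 8000 nM, with a range from 2000 nM to 30000 nM.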

Compound 4, half-maximal inhibitory concentration: 8900 nM
Compound 4: the middle estimate sits 1.1-fold (0.05 log units) below what was measured; the measured number falls inside the stated range.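

In this assay, chloro in place of hydrogen, ortho to a trifluoromethyl group, gives an at least 1.1-fold lower number from compound 2 to compound 4 (0.05 log units; that floor lies within the scatter), so this step alone does not establish a gain. The step remains only a floor because compound 2 gives a limit: the limit of > 10000 nM in this assay, at which 2 of the 4 values shown sit. With chloro held in place, the carbonyl substituent can now be read, and amino in place of methoxy gives a 3.0-fold higher number from compound 1 to compound 4 (0.47 log units; beyond the scatter). What the compounds shown leave open is whether fluoro or methyl at the chloro position would behave alike, and how a carboxylic acid or a longer ester would compare at the carbonyl carbon.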